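Replacing the group on the ether oxygen of compound 2

The source may hold more compounds than are shown below. What is called first, only, known or untested is meant among the compounds shown, and "the series" means these compounds.

In an ADME assay on microsomes from liver (Homo sapiens) for metabolic stability (a lower number here means slower removal, a higher number faster removal of the compound), compound 1 (`CCn1cnc2c(-c3ccc(F)c(-c4cnn(C)c4)c3)cnnc21`) gives 47 mL.min-1.g-1 and compound 2 (`CCn1cnc2c(-c3ccc(F)c(OCc4ccccn4)c3)cnnc21`) gives 41 mL.min-1.g-1 so these two values lie within the scatter of each other. Compound 3 (`CCn1cnc2c(-c3ccc(F)c(Oc4cnc(C#N)nc4)c3)cnnc21`) keeps the core of compound 2 but changes what sits on the oxygen on an aromatic ring (2-cyanopyrimidin-5-yl in place of (pyridin-2-yl)methyl on an oxygen on an aromatic ring). Within the data shown here, the only measured step that bears on this (a 1.1-fold lower number from compound 1 to compound 2 (0.06 log units; within the scatter)) exchanged a different pair of groups, so it gives only loose guidance. No shift beyond the scatter is expected in this assay, and the expected step (a 1.2-fold lower number from compound 2 to compound 3 (0.07 log units; within the scatter)) is small. The estimated value for compound 3 is 35 mL.min-1.g-1 (expected range 15 mL.min-1.g-1 to 75 mL.min-1.g-1).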

Compound 3, intrinsic clearance in microsomes: 49 mL.min-1.g-1
The estimate for compound 3 lay 1.4-fold (0.15 log units) below the measured number; low and high end bracket the measured number.
By their numbers in this assay, from the lowest: compounds 2, 1 and 3 (each within the scatter of the next).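

In this assay, 2-cyanopyrimidin-5-yl on the oxygen proves no different from (pyridin-2-yl)methyl, with a 1.2-fold higher number from compound 2 to compound 3 (0.08 log units; within the scatter). The comparison with the 1-methyl-1H-pyrazol-4-yl group of compound 1 gives a 1.0-fold higher number from compound 1 to compound 3 (0.02 log units; within the scatter), so three quite different aromatic groups now fall within the scatter of one another. No supporting measurement offers a reason for this result. On these data alone, all three groups contain an aromatic ring, so it remains open whether a non-aromatic group, such as a simple methyl or a chain ending in an amine, would shift this number beyond the scatter.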